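Swapping a dichlorobenzyl ether for a methylsulfonyl ester

The source may hold more compounds than are shown below. What is called first, only, known or untested is meant among the compounds shown, and "the series" means these compounds.

Measured compounds:
- compound 1, `COc1cc(-c2nc3ccccc3c(=O)[nH]2)ccc1OCc1ccc(Cl)cc1Cl`: 24.1%
- compound 2, `O=c1[nH]c(-c2ccc(OS(=O)(=O)c3ccccc3)cc2)nc2ccccc12`: 19.3%
- compound 3, `COc1ccc(-c2nc3ccccc3c(=O)[nH]2)cc1OCc1ccc(F)cc1F`: 23.8%

Of the compounds shown here, three sharing one core have been tested in an ADME assay on cells for inhibition of cytochrome P450 1A1 (Homo sapiens), read by fluorescence, tested at 10 uM; on this read-out higher numbers stand for more inhibition at the one concentration tested (going by the name of the read-out) and lower numbers for less inhibition. Compound 1 gives 24.1%, which is the highest of the three numbers, yet compound 3 with 23.8% and compound 2 with 19.3% both lie within the usual scatter of it, so none of the three can be set apart from the others on these readings. All three sit in the lower part of the scale, meaning only modest inhibition at the single concentration tested.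

The next compound, compound 4, `COc1cc(-c2nc3ccccc3c(=O)[nH]2)ccc1OS(C)(=O)=O`, has not yet been measured in this assay. It differs from compound 1 in one place: methylsulfonyl in place of 2,4-dichlorobenzyl on an oxygen on an aromatic ring. Among the measured compounds shown here, no step between two measured compounds isolates this kind of change. For the measured compounds named here, the only hint is compound 2, which also carries a sulfonyl group on an aromatic oxygen and gives 19.3%, a number that does not fall outside the scatter of the others.

Compound 4 is therefore expected to stay near the range already seen, with an estimated a number 7.1 percentage points lower from compound 1 to compound 4 (within the scatter) that does not go beyond the scatter. The value of compound 4 in this assay is estimated at 17%, most likely between 5% and 30%.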

Compound 4, a percentage reported as inhibition, at one concentration (the size of the read-out at that concentration, not a potency): 12%
Compound 4: the middle estimate sits 5 percentage points above what was measured; the measured number falls inside the stated range.
By their numbers in this assay, from the lowest: compounds 4, 2, 3 and 1 (each within the scatter of the next, the first and the last beyond it).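

In this assay, among the compounds shown here, methylsulfonyl in place of 2,4-dichlorobenzyl on an oxygen on an aromatic ring gives a number 12.1 percentage points lower from compound 1 to compound 4 (beyond the scatter), the first step here that isolates one change and one that clears the usual scatter. For the compounds shown here, it shows that the group on this oxygen can shift the reading, which the three earlier compounds could not show, as they all lay within scatter of their nearest neighbours and no pair differed in one place. The change swaps several features at once: the 9 heavy atoms and aromatic ring of the leaving group give way to 4 heavy atoms, no ring and 2 hydrogen-bond acceptors, and no supporting measurement says which of these differences matters.

The compounds shown leave open whether the drop follows the loss of the ring, the loss of the chlorine atoms or the arrival of the sulfonyl group. An unsubstituted benzyl group or a simple ethyl group on the same oxygen would help pull these apart, and the reading at one concentration says nothing yet about potency.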